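Swapping fluoro for bromo on a small inhibitor

The source may report more compounds than this note shows. Statements on the series, on what has been measured and on what is new or still open speak of the compounds shown alone.

In a functional assay on RAW264.7 cells (Mus musculus) for inhibition (a higher number here means a weaker inhibitor, a lower number a stronger inhibitor), compound 1 (`O=C(NS(=O)(=O)c1ccccc1)c1ccccn1`) gives 4500 nM and compound 2 (`O=C(NS(=O)(=O)c1ccc(F)cc1)c1ccccn1`) gives 3300 nM so the two stand level within the scatter, and neither can be called the better inhibitor. Compound 3 (`O=C(NS(=O)(=O)c1ccc(Br)cc1)c1ccccn1`) keeps the shared core and carries bromo in place of fluoro on an aromatic carbon, para to a large group (bromo in place of fluoro on an aromatic carbon). Among the compounds with values here, only one measured step bears on this change, a 1.4-fold lower number from compound 1 to compound 2 (0.13 log units; within the scatter) with fluoro in place of hydrogen on an aromatic carbon. Within the data shown here, no measured compound carries bromo, so that small step offers the only guide, and no shift beyond the scatter is expected in this assay in either direction. The expected step is a 1.2-fold lower number from compound 2 to compound 3 (0.07 log units; within the scatter) and stays within the usual scatter. Compound 3 is therefore estimated at 2800 nM (expected range 1100 nM to 7000 nM).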

Compound 3, half-maximal inhibitory concentration: 1900 nM
Compound 3: the middle estimate sits 1.5-fold (0.17 log units) above what was measured; the measured number falls inside the stated range.
By their numbers in this assay, from the lowest: compounds 3, 2 and 1 (each within the scatter of the next, the first and the last beyond it).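

In this assay, within the data shown here, this position does respond to a change: bromo in place of hydrogen gives a 2.4-fold lower number from compound 1 to compound 3 (0.37 log units; beyond the scatter) and this modest step is the first here to clear the scatter. The direct swap of fluoro for bromo gives a 1.7-fold lower number from compound 2 to compound 3 (0.24 log units; within the scatter) so compound 2 and compound 3 cannot be ranked against each other, and the difference shows only when compound 3 is set against compound 1. Nothing available explains why this step occurs.

On these data alone, whether a methoxy group, an amine or a carboxylic acid at this position would lower the number further, or raise it, remains open. Also open, as far as these compounds go, is whether bromo would give a similar step if another part of the shared core were changed.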